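A New Group on the Ring Nitrogen of Compound 3

The compounds below may be only part of what the source reports. "The series", "measured", "known", "first", "only" and "open" are said of these compounds alone.

Three compounds have been measured in a functional assay on HeLa cells (Homo sapiens) for inhibition, read by MTT assay; on this read-out lower numbers stand for stronger inhibition and higher numbers for weaker inhibition:

Compound 1 `CCCCCCCCn1cc(/C=C/C(=O)c2ccc(NC(=O)CN3CCN(C(=O)OC(C)(C)C)CC3)cc2)nn1` gives 32100 nM
Compound 2 `CC(C)(C)OC(=O)N1CCN(CC(=O)Nc2ccc(C(=O)/C=C/c3cn(Cc4ccc(Br)cc4)nn3)cc2)CC1` gives 18900 nM
Compound 3 `CCCCCCCCCCn1cc(/C=C/C(=O)c2ccc(NC(=O)CN3CCN(C(=O)OC(C)(C)C)CC3)cc2)nn1` gives 30200 nM

Compound 3 stands second highest of the three numbers; its nearest neighbour is compound 1, as seen in a 1.1-fold lower number from compound 1 to compound 3 (0.03 log units; within the scatter), and its furthest is compound 2, as seen in a 1.6-fold higher number from compound 2 to compound 3 (0.20 log units; within the scatter). Compound 4 `CCCCCCCCCCn1cc(/C=C/C(=O)c2ccc(NC(=O)CN3CCN(c4ccccc4OC)CC3)cc2)nn1` differs from compound 3 by 2-methoxyphenyl in place of tert-butoxycarbonyl on an amine nitrogen in a ring. Among the compounds with values here, none of the measured steps touches that ring nitrogen: a 1.7-fold lower number from compound 1 to compound 2 (0.23 log units; within the scatter) and the two others all change the chain on the aromatic nitrogen, and all stay within the scatter. Within the data shown here, with no step bearing on this change, no shift beyond the scatter is expected, so the estimated step is a 1.2-fold lower number from compound 3 to compound 4 (0.08 log units; within the scatter). Compound 4 is therefore expected to give about 25000 nM in this assay, within 6000 nM to 100000 nM.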

Compound 4, half-maximal inhibitory concentration: 50800 nM
Compound 4: middle estimate off by 2.0-fold (0.31 log units), on the low side; the measured number falls inside the stated range.
By their numbers in this assay, from the lowest: compounds 2, 3, 1 and 4 (each within the scatter of the next, the first and the last beyond it).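

Within the data shown here, this is the first step at the amine nitrogen in the ring, and replacing tert-butoxycarbonyl with 2-methoxyphenyl gives a 1.7-fold higher number from compound 3 to compound 4 (0.23 log units; within the scatter) in this assay. A group with a six-membered aromatic ring can therefore stand at this position in place of one with no ring, without a shift beyond the scatter. No measurement here bears on the size of this step.

On these data alone, whether a plain hydrogen, an acetyl group or a benzyl group on this nitrogen would move the number beyond the scatter stays open. So does whether 2-methoxyphenyl behaves the same with the 4-bromophenyl group of compound 2 on the aromatic nitrogen.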